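The source may report more compounds than this note shows. Statements on the series, on what has been measured and on what is new or still open speak of the compounds shown alone.

Compound 1 `COc1cccc(Oc2c(NS(=O)(=O)c3ccc(C(C)(C)C)cc3)ncnc2OCCOc2ccccc2)c1`: 65 nM
Compound 2 `COc1cccc(Oc2c(NS(=O)(=O)c3ccc(C(C)(C)C)cc3)ncnc2OCCOc2ncc(C)cn2)c1`: 0.86 nM
Compound 3 `COc1cccc(Oc2c(NS(=O)(=O)c3ccc(C(C)(C)C)cc3)ncnc2OCCOc2ncc(Br)cn2)c1`: 0.051 nM

In an assay on cells (Endothelial cell) for binding affinity to Endothelin-1 receptor (Sus scrofa) (a higher number here means a weaker inhibitor, a lower number a stronger inhibitor), compound 3 stands lowest of the three; the nearest step to it is a 17-fold lower number from compound 2 to compound 3 (1.23 log units; beyond the scatter) and the furthest is a 1300-fold lower number from compound 1 to compound 3 (3.11 log units; beyond the scatter). Compound 4 `COc1cccc(Oc2c(NCCOc3ncccn3)ncnc2NS(=O)(=O)c2ccc(C(C)(C)C)cc2)c1` differs from compound 3 in one place: (2-((pyrimidin-2-yl)oxy)ethyl)amino in place of 2-((5-bromopyrimidin-2-yl)oxy)ethoxy on an aromatic carbon. Going by the values given here, two measured steps bear on this change. One swaps exactly the substituent that compound 4 loses: a 17-fold lower number from compound 2 to compound 3 (1.23 log units; beyond the scatter). The other shows how much the ring on that chain can move the number: a 76-fold lower number from compound 1 to compound 2 (1.88 log units; beyond the scatter). Among the compounds with values here, no measured step covers the exchange of the oxygen link for an amino link. A large rise in the number is therefore expected for compound 4, a 98-fold higher number from compound 3 to compound 4 (1.99 log units; beyond the scatter), with added uncertainty from the linker. Compound 4 is estimated at 5 nM, within a range from 0.5 nM to 50 nM.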

Compound 4, half-maximal inhibitory concentration: 6.2 nM
Compound 4: the middle estimate sits 1.2-fold (0.09 log units) below what was measured; the measured number falls inside the stated range.
By their numbers in this assay, from the lowest: compound 3; then compound 2; then compound 4; then compound 1.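

In this assay, the (2-((pyrimidin-2-yl)oxy)ethyl)amino chain still beats the 2-phenoxyethoxy chain, with a 10-fold lower number from compound 1 to compound 4 (1.02 log units; beyond the scatter), so this position accepts an amino link without losing all of the benefit seen with the pyrimidine chains. It nevertheless falls short of both substituted pyrimidine chains, with a 7.2-fold higher number from compound 2 to compound 4 (0.86 log units; beyond the scatter) and a 120-fold higher number from compound 3 to compound 4 (2.08 log units; beyond the scatter). These steps change the link and the ring substituent together, and no measurement available here explains the loss. On these data alone, the separate contributions remain open: a 5-bromopyrimidin-2-yl ring on the amino chain, or an unsubstituted 2-((pyrimidin-2-yl)oxy)ethoxy chain, would divide them.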